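A Bromo-Methoxyphenyl Swap on a Shared Core

This account rests on a few compounds, and the source may have more. Where it says the series, first, only, none or still open, it means among the compounds named here.

This account follows compound 1 `COc1cc(NC(=O)Nc2cc(Nc3cccc(C(C)(C)C)c3)ncn2)cc(OC)c1` into compound 3 `COc1cc(NC(=O)Nc2cc(Nc3cc(Br)ccc3OC)ncn2)cc(OC)c1`. In a functional assay on NCI-H1581 cells (Homo sapiens) for inhibition, read by MTT assay, with a stated time of 48 h, tested at 10 uM (on this read-out higher numbers stand for more inhibition at the one concentration tested (going by the name of the read-out) and lower numbers for less inhibition), compound 1 gives 35.1%, the lower of the two numbers at hand. Compound 2 `COc1ccc(C(F)(F)F)cc1Nc1cc(NC(=O)Nc2c(Cl)cccc2Cl)ncn1` shares the core but differs from compound 1 in several places; in this assay compound 2 gives 69.1%. The gap to compound 1 lies beyond the usual scatter, yet with several places changed at once nothing can be drawn from it about any single change. Compound 3 differs from compound 1 in one place: 5-bromo-2-methoxyphenyl in place of 3-(tert-butyl)phenyl on a nitrogen on an aromatic ring. Among the measured compounds shown here, no measured pair shows this change, so the expectation rests on compound 1 alone. A small upward step is expected, a number 6.9 percentage points higher from compound 1 to compound 3 (within the scatter), though a step of none beyond the scatter in either direction would not surprise. Compound 3 is therefore estimated to give 42% in this assay, within a range from 18% to 66%.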

Compound 3, a percentage reported as inhibition, at one concentration (the size of the read-out at that concentration, not a potency): 23.1%
Beside the measured number, compound 3's estimate is 18.9 percentage points above it; low and high end bracket the measured number.
By their numbers in this assay, from the lowest: compound 3; then compound 1; then compound 2.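

In this assay, among the compounds shown here, 5-bromo-2-methoxyphenyl in place of 3-(tert-butyl)phenyl on a nitrogen on an aromatic ring gives a number 12 percentage points lower from compound 1 to compound 3 (beyond the scatter), the first reading of a single change on the shared core. It shows that the read-out responds to the group at this position, and that a group bringing in oxygen and bromine, where the group it replaces holds carbon only, does not raise the number here. No measurement at hand accounts for the step.

Going by these compounds, the bromine and the methoxy enter together, so it remains open which of them, if either alone, carries the step. On these data alone, it also remains open how the number would move with an unsubstituted phenyl at this position, or with a phenyl bearing an amine or a carboxylic acid.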